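Replacing trifluoromethyl with hydrogen: working notes

The compounds below may be only part of what the source reports. "The series", "measured", "known", "first", "only" and "open" are said of these compounds alone.

Compounds so far in a functional assay on MKN-45 cells (Homo sapiens) for antiproliferative activity, with a stated time of 72 h; on this read-out higher numbers stand for weaker inhibition and lower numbers for stronger inhibition:
- compound 1 `Cn1cc(-c2ccc(NC(=O)c3cn(CC4CCOCC4)cc(-c4ccc(Cl)cc4)c3=O)cc2)c2c(N)ncnc21` gives 347 nM so far
- compound 2 `Cn1cc(-c2ccc(NC(=O)c3cn(CC4CCOCC4)cc(-c4ccc(C(F)(F)F)cc4)c3=O)cc2)c2c(N)ncnc21` gives 826 nM so far
- compound 3 `Cn1cc(-c2ccc(NC(=O)c3cn(CC4CCOCC4)cc(-c4ccccc4)c3=O)cc2)c2c(N)ncnc21` is not yet measured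

Compound 2 holds the higher of the two numbers, with compound 1 nearest. The change to compound 3 is hydrogen in place of trifluoromethyl on an aromatic carbon (hydrogen in place of trifluoromethyl on an aromatic carbon, para to a large group). Among the measured compounds shown here, the only measured step bearing on it is modest: a 2.4-fold higher number from compound 1 to compound 2 (0.38 log units; beyond the scatter) with trifluoromethyl in place of chloro. For the measured compounds named here, no measured compound carries the hydrogen, so the support is thin. In this assay a modest move to a lower number is expected (a 2.1-fold lower number from compound 2 to compound 3 (0.31 log units; beyond the scatter)) on that single step. For compound 3 the estimated value is 400 nM within an expected range of 150 nM to 1100 nM for now.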

Compound 3, half-maximal inhibitory concentration: 318 nM
Compound 3: middle estimate off by 1.3-fold (0.10 log units), on the high side, within the range that was stated.
By their numbers in this assay, from the lowest: compounds 3 and 1 (each within the scatter of the next); then compound 2.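

In this assay, taking trifluoromethyl off the ring gives a 2.6-fold lower number from compound 2 to compound 3 (0.41 log units; beyond the scatter), whereas hydrogen in place of chloro gives a 1.1-fold lower number from compound 1 to compound 3 (0.04 log units; within the scatter). On this aromatic carbon, hydrogen and chloro therefore cannot be told apart, and among the three groups only trifluoromethyl, in compound 2, stands apart. Nothing available explains why trifluoromethyl differs from the other two. Going by these compounds, it remains open whether a methoxy group, a nitrile or a dimethylamino group at this place would read with hydrogen and chloro or with trifluoromethyl.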